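Thioether series: bromophenyl to methylphenyl on the benzyl arm

The compounds below may be only part of what the source reports. "The series", "measured", "known", "first", "only" and "open" are said of these compounds alone.

Measured compounds, all in an ADME assay on isolated protein for inhibition of Amine oxidase [flavin-containing] B (Homo sapiens); a lower number here means a stronger inhibitor, a higher number a weaker inhibitor:
compound 1, `C#CCNC1CCc2c(NCc3cccc(C(F)(F)F)c3)cccc21`, gives 11300 nM.
compound 2, `C#CCNC1CCc2c(SCc3cccc(Br)c3)cccc21`, gives only a limit, > 100000 nM.
compound 3, `C#CCNC1CCc2c(SCCc3cccc(C)c3)cccc21`, gives 4960 nM.

Within the data shown here, compound 2 stands at the top of the measured range; its entry is a limit of this assay and not a number, and it is the one value that sits at the limit of > 100000 nM in this assay, at which 1 of the 3 values shown sits. Among the measured compounds shown here, no step between two measured compounds is available in this assay, so the size of the change from compound 2 to compound 4 can only be expected, not read off. Compound 4, `C#CCNC1CCc2c(SCc3ccc(C)cc3)cccc21`, differs from compound 2 by 4-methylphenyl in place of 3-bromophenyl on a saturated chain carbon bound to a sulfur. For compound 4 a step toward a stronger inhibitor, an at least 2.5-fold lower number from compound 2 to compound 4 (0.39 log units; beyond the scatter), is expected, with a fair chance that this assay again returns only a limit. Compound 4 is estimated at 40000 nM in this assay, in the range 8000 nM to 200000 nM.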

Compound 4, half-maximal inhibitory concentration: 320 nM
Beside the measured number, compound 4's estimate is 130-fold (2.10 log units) above it; measured number below the stated range.
By their numbers in this assay, from the lowest: compound 4; then compound 3; then compound 1. At a limit, above all of these: compound 2.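

In this assay, 4-methylphenyl in place of 3-bromophenyl on a saturated chain carbon bound to a sulfur gives an at least 310-fold lower number from compound 2 to compound 4 (2.49 log units; beyond the scatter), so the aryl group at this place strongly affects the read-out in the thioether series. The entry for compound 2 is a limit and not a number, so the full size of this step stays unknown: the limit of > 100000 nM in this assay, at which 1 of the 4 values shown sits.

This single step changes both the substituent and where it sits on the ring, and the two effects cannot be told apart. A 4-bromophenyl or 3-methylphenyl group at the same place would separate them.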